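Sulfonyl substituent change in a weakly active K562 pair

This account rests on a few compounds, and the source may have more. Where it says the series, first, only, none or still open, it means among the compounds named here.

Measured so far:
compound 1 `Cn1c(=O)c(S(=O)(=O)Cc2ccc(F)cc2)cc2cnc(Nc3ccc4[nH]ccc4c3)nc21` — 30000 nM
compound 2 `Cn1c(=O)c(S(=O)(=O)c2ccc(Cl)cc2)cc2cnc(Nc3cnc4ccccc4c3)nc21` — 15000 nM

In a functional assay on K562 cells (Homo sapiens) for inhibition, read by trypan blue exclusion, with a stated time of 72 h (on this read-out higher numbers stand for weaker inhibition and lower numbers for stronger inhibition), compound 1 gives 30000 nM, and compound 2 gives 15000 nM; the two values lie within the scatter of each other, so neither stands apart. Compound 3 `Cn1c(=O)c(S(=O)(=O)c2ccc(O)cc2)cc2cnc(Nc3ccc4[nH]ccc4c3)nc21` is not yet measured. It differs from compound 1 by 4-hydroxyphenyl in place of 4-fluorobenzyl on a sulfonyl sulfur. Among the compounds with values here, no pair of measured compounds separates the effect of that change, so no step beyond the scatter is expected in this assay. Compound 3 is estimated at 20000 nM (range 5000 nM to 60000 nM), an expected step of a 1.5-fold lower number from compound 1 to compound 3 (0.18 log units; within the scatter).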

Compound 3, half-maximal inhibitory concentration: 100 nM
Beside the measured number, compound 3's estimate is 200-fold (2.30 log units) above it; measured number below the stated range.
By their numbers in this assay, from the lowest: compound 3; then compounds 2 and 1 (each within the scatter of the next).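

In this assay, the group on the sulfonyl sulfur proves a highly sensitive site: 4-hydroxyphenyl in place of 4-fluorobenzyl gives a 300-fold lower number from compound 1 to compound 3 (2.48 log units; beyond the scatter) with the rest of the structure unchanged. The earlier values, within the scatter of each other, gave no sign of this. No measurement on hand explains the step.

On these data alone, the change alters both the benzyl-to-phenyl connection and the ring substituent, so the part responsible remains open. 4-Hydroxybenzyl or 4-fluorophenyl would separate the two, and 4-aminophenyl would test whether another group can replace the hydroxyl.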